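A few compounds are considered here, and "the series" means these few. Any claim that something is new, unique, unknown or untested is made for them only; others in the source may bear on it.

Compound 1 `CO[C@@H]1CC=C2NN(c3cc4ccccc4[nH]3)C(=O)C[C@]2(c2ccccc2)O1` carries a phenyl group on a saturated ring carbon of its core, and in a functional assay on HCT-116 cells (Homo sapiens) for inhibition, read by sulforhodamine B assay, with a stated time of 48 h (a higher number here means a weaker inhibitor, a lower number a stronger inhibitor), compound 1 gives 8200 nM. Compound 2 `COc1cc(OC)cc(N2NC3=CC[C@@H](OC)O[C@@]3(c3ccccc3)CC2=O)c1` has a different core, and in this assay compound 2 gives 18100 nM. How the two cores differ is not broken down here. Compound 3 `COc1cc(OC)cc(N2NC3=CC[C@@H](OC)O[C@@]3(c3ccncc3)CC2=O)c1` is the partner of compound 2 in which pyridin-4-yl stands in place of phenyl, with the change (pyridin-4-yl in place of phenyl on a saturated ring carbon), and in this assay compound 3 gives 6500 nM. That change gave a 2.8-fold lower number from compound 2 to compound 3 (0.44 log units; beyond the scatter). Compound 4 `CO[C@@H]1CC=C2NN(c3cc4ccccc4[nH]3)C(=O)C[C@]2(c2ccncc2)O1` is the not yet measured partner of compound 1 that carries the same kind of change, (pyridin-4-yl in place of phenyl on a saturated ring carbon). The surroundings of the place are described differently in the two pairs: in compound 1 the saturated ring carbon sits in a six-membered non-aromatic ring with 1 oxygen, next to the ring oxygen, next to the ring atom that bears a fused ring, and two ring bonds from the ring atom that bears a methoxy group, whereas in compound 2 it sits in a six-membered non-aromatic ring with 2 nitrogen, two ring bonds from the ring nitrogen, three ring bonds from the ring nitrogen, and three ring bonds from the ring atom that bears a large group. Within the data shown here, only one measured example of this change exists, so the expectation rests on it alone. In this assay compound 4 is expected to show a 2.7-fold lower number from compound 1 to compound 4 (0.44 log units; beyond the scatter), resting on a 2.8-fold lower number from compound 2 to compound 3 (0.44 log units; beyond the scatter) seen for the same kind of change. Compound 4 is therefore estimated at 3000 nM in this assay, with a range from 1400 nM to 7500 nM.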

Compound 4, half-maximal inhibitory concentration: 4350 nM
Compound 4: middle estimate off by 1.5-fold (0.16 log units), on the low side, within the range that was stated.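

In this assay, pyridin-4-yl in place of phenyl on a saturated ring carbon gives a 1.9-fold lower number from compound 1 to compound 4 (0.28 log units; within the scatter), so on the core of compound 1 this step alone cannot be told apart from the scatter of repeated measurements. The result therefore does not establish a real gain on that core, and two pairs, one on each core, cannot show that the change would behave alike on any further core in the series. What it does show is that the two steps point the same way and that their sizes cannot be distinguished, so nothing here indicates that the change loses or alters its effect when carried between these two cores: the same change on two cores in this assay, a 2.8-fold lower number (0.44 log units; beyond the scatter) from compound 2 to compound 3 and a 1.9-fold lower number (0.28 log units; within the scatter) from compound 1 to compound 4, 1.5-fold (0.17 log units) apart, within the scatter of two such steps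

The compounds shown leave open whether the gain depends on the nitrogen of pyridin-4-yl in particular, since they hold neither pyridin-3-yl nor pyridin-2-yl, nor a phenyl bearing a fluorine or a methoxy group, at this saturated ring carbon. They also leave open how either core would respond if the methoxy group on its oxygen-containing ring gave way to a hydroxyl group or a longer ethoxy chain.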